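The compounds below may be only part of what the source reports. "The series", "measured", "known", "first", "only" and "open" are said of these compounds alone.

Measured compounds:
- compound 1, `CCCCCCCCCCCCCC[C@H](O)[C@H](CO[Si](c1ccccc1)(c1ccccc1)C(C)(C)C)NC(=O)OC(C)(C)C`: 3.11%
- compound 2, `CCCCCCCCCCCCCC[C@H](OCOC)[C@H](CO[Si](c1ccccc1)(c1ccccc1)C(C)(C)C)NC(=O)OC(C)(C)C`: -2.89%
- compound 3, `CCCCCCCCCCCCCC[C@H](OCOC)[C@H](CO)NC(=O)OC(C)(C)C`: 18.4%

In a functional assay on NCI-H358 cells (Homo sapiens) for antiproliferative activity, read by sulforhodamine B assay, with a stated time of 48 h, tested at 10 uM (a lower number here means less inhibition, a higher number more inhibition at the concentration tested (going by the name of the read-out)), compound 3 stands highest of the three measured compounds; its nearest neighbour is compound 1, and its furthest is compound 2, both gaps lying beyond the usual scatter. Compound 2 and compound 3 differ only at the carbon bearing the silyl ether or the free hydroxy group, and their two values show a clear difference in this assay. Among the compounds with values here, the one measured step, a number 6 percentage points lower from compound 1 to compound 2 (within the scatter), concerns a change on an oxygen and lies within the scatter.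

Compound 4, `CCCCCCCCCCCCCC[C@H](OCOC)[C@H](CN(CC)CC)NC(=O)OC(C)(C)C`, follows from compound 3 by the change (diethylamino in place of hydroxy on a saturated chain carbon, two bonds along the chain from an amide-type nitrogen). Within the data shown here, no measured step touches this kind of change: the only step recorded is the methoxymethyl for hydrogen exchange, which says nothing about replacing hydroxy with diethylamino. The expectation therefore rests on compound 3 alone, with a wide range. Compound 4 is estimated at 25% (range 3% to 55%), which means an expected step of a number 6.6 percentage points higher from compound 3 to compound 4 (within the scatter), not firmly beyond the scatter in either direction.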

Compound 4, a percentage reported as inhibition, at one concentration (the size of the read-out at that concentration, not a potency): 15%
Estimate against measurement, compound 4: 10 percentage points above; measured number inside the range.
By their numbers in this assay, from the lowest: compounds 2 and 1 (each within the scatter of the next); then compounds 4 and 3 (each within the scatter of the next).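

In this assay, putting diethylamino in place of hydroxy on a saturated chain carbon, two bonds along the chain from an amide-type nitrogen, gives a number 3.4 percentage points lower from compound 3 to compound 4 (within the scatter), so this one pair shows no difference beyond the scatter. At this position, five heavy atoms can stand in place of one, and the hydrogen-bond donor of the hydroxy can be absent, without the reading moving outside that scatter. Nothing on hand bears on why the two compounds read alike.

Open, from the compounds shown here alone, is how a primary amine or a carboxylic acid on this same carbon would read in this assay. Also open, going by these compounds, is whether the exchange of hydroxy for diethylamino would read alike with a free hydroxy in place of the methoxymethyl ether on the chain.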